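Enaminone series: aryl ketone variation on compound 1

The source may report more compounds than this note shows. Statements on the series, on what has been measured and on what is new or still open speak of the compounds shown alone.

Measured so far:
compound 1 `COc1cc(C(=O)/C=C\Nc2ccc(-c3nc4cc(OC)c(OC)c(OC)c4s3)cc2C)cc(OC)c1OC`: 12900 nM
compound 2 `COc1cc(OC)c2sc(-c3ccc(N/C=C\C(=O)c4ccc(OC)c(O)c4)c(C)c3)nc2c1`: 3100 nM
compound 3 `COc1cc(C(=O)/C=C\Nc2ccc(-c3nc4cc(OC)c(OC)c(OC)c4s3)cc2C)c(Br)c(OC)c1OC`: 7300 nM

In a functional assay on MDA-MB-231 cells (Homo sapiens) for antiproliferative activity, read by sulforhodamine B assay, with a stated time of 48 h (on this read-out higher numbers stand for weaker inhibition and lower numbers for stronger inhibition), compound 1 stands highest of the three numbers. Compound 3, with bromo in place of hydrogen on an aromatic carbon, gives a 1.8-fold lower number from compound 1 to compound 3 (0.25 log units; within the scatter). Compound 2, which carries a different aryl group on the carbonyl carbon, gives a number beyond the scatter below that of compound 1.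

Compound 4 `COc1ccc(C(=O)/C=C\Nc2ccc(-c3nc4cc(OC)c(OC)c(OC)c4s3)cc2C)cc1[N+](=O)[O-]` differs from compound 1 by 4-methoxy-3-nitrophenyl in place of 3,4,5-trimethoxyphenyl on a carbonyl carbon. Going by the values given here, no measured step covers this exact change; only the values of compound 1 and compound 2 show that altering the aryl ketone can move this assay beyond the scatter. Compound 4 is expected to give a 1.6-fold lower number from compound 1 to compound 4 (0.21 log units; within the scatter), estimated at 8000 nM with a range of 2500 nM to 25000 nM.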

Compound 4, half-maximal inhibitory concentration: 12400 nM
For compound 4 the middle estimate is 1.6-fold (0.19 log units) below the measured one, and the stated range covers the measured number.
By their numbers in this assay, from the lowest: compound 2; then compounds 3, 4 and 1 (each within the scatter of the next).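

In this assay, 4-methoxy-3-nitrophenyl in place of 3,4,5-trimethoxyphenyl on the carbonyl carbon gives a 1.0-fold lower number from compound 1 to compound 4 (0.02 log units; within the scatter). This aryl ketone position therefore accepts a nitro-bearing ring with a single methoxy group without any readable difference from the trimethoxyphenyl ring. Nothing on hand accounts for this result.

Going by these compounds, the step changes the nitro and methoxy groups together, so their separate contributions remain open. Also open, on these data alone, is how an amine or a carboxylic acid in place of the nitro group would read in this assay.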